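The compounds below may be only part of what the source reports. "The series", "measured", "known", "first", "only" and "open" are said of these compounds alone.

Measured compounds:
compound 1, `COc1nc2ccc(Br)cc2cc1C(c1ccccc1)n1cc(C2CC2)nn1`, gives -5.84% in an ADME assay on HeLa cells (Homo sapiens) for cytotoxicity, read by sulforhodamine B assay, with a stated time of 48 h, tested at 10 uM; a lower number here means less inhibition, a higher number more inhibition at the concentration tested (going by the name of the read-out);
compound 2, `CCCCc1cn(C(c2ccccc2)c2cc3cc(Br)ccc3nc2OC)nn1`, gives -2.87% in this assay;
compound 3, `COc1nc2ccc(Br)cc2cc1C(c1ccccc1)n1cc(-c2ccc(OC(F)(F)F)cc2)nn1`, gives -2.24% in this assay.

Compound 3 holds the highest of the three numbers, yet its nearest neighbour compound 2 and its furthest neighbour compound 1 both sit within the scatter of it. Compound 4, `COc1nc2ccc(Br)cc2cc1C(c1ccccc1)n1cc(CCCO)nn1`, differs from compound 3 by 3-hydroxypropyl in place of 4-(trifluoromethoxy)phenyl on an aromatic carbon. Every measured step changes the group on that same aromatic carbon: a number 3 percentage points higher from compound 1 to compound 2 (within the scatter), a number 3.6 percentage points higher from compound 1 to compound 3 (within the scatter) and a number 0.6 percentage points higher from compound 2 to compound 3 (within the scatter), all within the scatter. On that basis no step beyond the scatter is expected in this assay for compound 4, estimated as a number 0.8 percentage points lower from compound 3 to compound 4 (within the scatter). Compound 4 is therefore estimated at -3%, within -13% to 7%.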

Compound 4, a percentage reported as inhibition, at one concentration (the size of the read-out at that concentration, not a potency): 11.3%
For compound 4 the middle estimate is 14.3 percentage points below the measured one; measured number outside the range, above it.
By their numbers in this assay, from the lowest: compounds 1, 2 and 3 (each within the scatter of the next); then compound 4.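

On this aromatic carbon the group can shift the result in this assay: 3-hydroxypropyl gives steps beyond the scatter against 4-(trifluoromethoxy)phenyl (a number 13.5 percentage points higher from compound 3 to compound 4 (beyond the scatter)) and cyclopropyl (a number 17.1 percentage points higher from compound 1 to compound 4 (beyond the scatter)), unlike any exchange among the earlier groups. Among these compounds, the single change of hydroxy in place of methyl on the saturated chain is enough for a step of this kind (a number 14.2 percentage points higher from compound 2 to compound 4 (beyond the scatter)). No measurement available explains this step. From the compounds shown here alone, it remains open whether hydroxy itself matters, or whether an amine or a carboxylic acid in its place would give a similar number. Going by these compounds, a shorter or longer hydroxyalkyl chain also remains untested here.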